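Chloro on a pyridinyl amide: expected growth inhibition

The source may hold more compounds than are shown below. What is called first, only, known or untested is meant among the compounds shown, and "the series" means these compounds.

Compound 1 `O=C(CCCCC(S)CCS)Nc1ccccc1` and compound 2 `O=C(CCCCC(S)CCS)Nc1ccc(Cl)cc1` share a thiol-bearing chain linked through an amide to an aromatic ring. In a functional assay on KB cells (Homo sapiens) for inhibition, read by MTT assay, with a stated time of 24 h, tested at 1 ug/mL (on this read-out lower numbers stand for less inhibition of growth and higher numbers for more inhibition of growth at the one concentration tested), compound 1 gives 11.6% and compound 2 gives 13.4%; the change chloro in place of hydrogen on an aromatic carbon made a step of a number 1.8 percentage points higher from compound 1 to compound 2 (within the scatter). Compound 3 `O=C(CCCCC(S)CCS)Nc1ccccn1` differs from compound 1 by pyridin-2-yl in place of phenyl on an amide-type nitrogen, and in this assay compound 3 was reported as "not active" (no number reported), with no number given. Compound 4 `O=C(CCCCC(S)CCS)Nc1ccc(Cl)cn1` differs from compound 3 by chloro in place of hydrogen on an aromatic carbon, the same kind of change as from compound 1 to compound 2, but here the place is on a ring with one nitrogen, two atoms from the ring nitrogen, rather than on a ring of carbon only. Because a number 1.8 percentage points higher from compound 1 to compound 2 (within the scatter) lay within the scatter, a similarly small step is expected here. Compound 4 is therefore estimated at 8%, from 0% to 20% in this assay.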

Compound 4, percent growth inhibition at one concentration: "not active" (no number reported)
For compound 4 the study gives words and no number, and the estimate cannot be compared.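

Compound 3 and compound 4 are both reported only as "not active" in this assay, so no step can be read between them. No measurement shown offers an explanation for this result. The compounds shown leave open whether chloro in place of hydrogen changes growth inhibition on a ring with one nitrogen.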